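Quaternary ammonium chain on the hydroxylated flavone core

The source may hold more compounds than are shown below. What is called first, only, known or untested is meant among the compounds shown, and "the series" means these compounds.

Measured so far:
Compound 1 `O=c1cc(-c2ccc(O)c(O)c2)oc2cc(O)ccc12` — 11000 nM
Compound 2 `C[N+](C)(C)CCCOc1c(-c2ccc(O)c(O)c2)oc2ccccc2c1=O` — 1200 nM
Compound 3 `O=c1c(OCCO)c(-c2ccc(O)c(O)c2)oc2cc(O)ccc12` — 21700 nM

In a functional assay for inhibition, with Rattus norvegicus as the target, using microsomes (on this read-out higher numbers stand for weaker inhibition and lower numbers for stronger inhibition), compound 3 gives the highest of the three numbers. The nearest is compound 1, which gives 11000 nM; the step of a 2.0-fold higher number from compound 1 to compound 3 (0.30 log units; within the scatter) stays within the scatter, so the two cannot be ordered. Compound 2 gives 1200 nM in this assay, and its gap to compound 3 lies beyond the scatter. Compound 2 carries the quaternary ammonium chain in place of the 2-hydroxyethoxy chain and lacks the hydroxy on the core that compounds 1 and 3 carry.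

Compound 4 `C[N+](C)(C)CCCOc1c(-c2ccc(O)c(O)c2)oc2cc(O)ccc2c1=O` is not yet measured. It differs from compound 3 as follows: a group of 5 heavy atoms (4 carbon, 1 nitrogen; no ring) in place of one oxygen atom, on a saturated chain carbon, two bonds along the chain from an oxygen on an aromatic ring

Among the measured compounds shown here, no measured step bears directly on this change. For the measured compounds named here, the only comparison of the quaternary ammonium chain is compound 2, which in this assay gives 1200 nM while compound 3 gives 21700 nM, and these two compounds also differ in the hydroxy on the core, a difference that between compound 1 and compound 3 came out within the scatter. A lower number is therefore expected for compound 4, with the step of an 8.7-fold lower number from compound 3 to compound 4 (0.94 log units; beyond the scatter) estimated beyond the scatter. Compound 4 is estimated at 2500 nM, in the range 800 nM to 8000 nM.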

Compound 4, half-maximal inhibitory concentration: 3800 nM
Compound 4: middle estimate off by 1.5-fold (0.18 log units), on the low side; low and high end bracket the measured number.
By their numbers in this assay, from the lowest: compound 2; then compound 4; then compounds 1 and 3 (each within the scatter of the next).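

Working notes on the chain position, read in this assay. With the hydroxylated core now held constant, the quaternary ammonium chain can be compared directly with the 2-hydroxyethoxy chain: a 5.7-fold lower number from compound 3 to compound 4 (0.76 log units; beyond the scatter) is a step beyond the scatter, though modest, and it is free of the core difference that clouded the earlier comparison with compound 2. The same pair of chains also behaves differently against the unsubstituted position, since a 2.9-fold lower number from compound 1 to compound 4 (0.46 log units; beyond the scatter) lies beyond the scatter while a 2.0-fold higher number from compound 1 to compound 3 (0.30 log units; within the scatter) stays within it, so a chain on this aromatic carbon moves the number only in the quaternary ammonium case among these compounds. Among the compounds shown here, the core hydroxy can also be read on its own for the first time, and a 3.2-fold higher number from compound 2 to compound 4 (0.50 log units; beyond the scatter) shows that hydroxy in place of hydrogen on an aromatic carbon goes with a higher number in the presence of this chain.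

No measurement at hand gives a reason for any of these steps.

Open, as far as these compounds go, is whether the lower numbers depend on the quaternary ammonium itself or on the chain that carries it, a question that a tertiary amine, a carboxylic acid or a longer chain at this position would address.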